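The source may report more compounds than this note shows. Statements on the series, on what has been measured and on what is new or still open speak of the compounds shown alone.

In a functional assay on MIA PaCa-2 cells (Homo sapiens) for inhibition, read by MTT assay, with a stated time of 48 h, tested at 10 uM (a lower number here means less inhibition of growth, a higher number more inhibition of growth at the concentration tested), compound 1 `Cc1oc2c([C@H]3CCN(C)C[C@H]3O)c(O)cc(O)c2c(=O)c1C(O)c1c(Cl)cccc1Cl` gives 0% and compound 2 `COc1ccc(C(O)c2c(C)oc3c([C@H]4CCN(C)C[C@H]4O)c(O)cc(O)c3c2=O)cc1Br` gives 3%. Going by the values given here, compound 2 therefore stands within the scatter of compound 1, the only other compound measured so far. Compound 3 `Cc1oc2c([C@H]3CCN(C)C[C@H]3O)c(O)cc(O)c2c(=O)c1C(O)c1cccc(Cl)c1Cl` keeps the shared core of compound 2 and changes a single group: 2,3-dichlorophenyl in place of 3-bromo-4-methoxyphenyl on a saturated chain carbon bound to an aromatic carbon and an oxygen on a saturated carbon. In words, 2,3-dichlorophenyl comes in place of 3-bromo-4-methoxyphenyl on a saturated chain carbon bound to an aromatic carbon and an oxygen on a saturated carbon. Among the compounds with values here, one measured step bears on this change, because it falls at the same place: a number 3 percentage points higher from compound 1 to compound 2 (within the scatter). That single swap, from 2,6-dichlorophenyl to 3-bromo-4-methoxyphenyl, stayed within the scatter, so no step beyond the scatter is expected here. The expected step is a number 1 percentage points higher from compound 2 to compound 3 (within the scatter). For compound 3 the estimated value is 4%, with an expected range from 0% to 16%.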

Compound 3, percent growth inhibition at one concentration: 2%
Beside the measured number, compound 3's estimate is 2 percentage points above it; low and high end bracket the measured number.
By their numbers in this assay, from the lowest: compounds 1, 3 and 2 (each within the scatter of the next).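

For the group on the saturated chain carbon bound to an aromatic carbon and an oxygen on a saturated carbon, this assay now gives two more readings: a number 1 percentage points lower from compound 2 to compound 3 (within the scatter), and a number 2 percentage points higher from compound 1 to compound 3 (within the scatter). Compound 3 therefore adds a second dichlorophenyl pattern, and neither changing where the two chlorines sit nor exchanging them for the bromine and methoxy of 3-bromo-4-methoxyphenyl moves the number beyond the scatter. Nothing measured here offers an explanation for this flat result.

On these data alone, all three compounds carry a substituted phenyl at this place, so it remains open whether a group of another kind, such as a simple amine, a carboxylic acid or a longer chain, would shift the number. The compounds shown also leave open whether changes elsewhere on the shared core would do so.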